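The source may hold more compounds than are shown below. What is called first, only, known or untested is meant among the compounds shown, and "the series" means these compounds.

The measured compounds:
Compound 1 `CCOC(=O)c1cn(-c2ccc(OCC)cc2)nn1`: in an assay on lysate for inhibition of patatin-like phospholipase domain-containing protein 2 (Mus musculus) (a higher number here means a weaker inhibitor, a lower number a stronger inhibitor), compound 1 gives > 200000 nM, which is a limit of the assay and not a number.
Compound 2 `CCOC(=O)c1cccc(-c2ccc(Br)cc2)c1`: in this assay compound 2 gives > 200000 nM, again a limit of the assay rather than a number.

Within the data shown here, compound 2 therefore stands at the limit itself, and the one other value shown sits at the same place (the limit of > 200000 nM in this assay, at which 2 of the 2 values shown sit). Among the measured compounds shown here, nothing here separates the two compounds, and no pair of measured compounds differs in a single place, so no measured step exists to lean on.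

The next compound, compound 3 `CCOC(=O)c1cccc(-c2ccc(C(C)=O)cc2)c1`, differs from compound 2 in one place: acetyl in place of bromo on an aromatic carbon. With compound 2 at a limit in this assay, the scale offers no measured number from which a direction could be read. The writer expects the change from compound 2 to compound 3 to produce no step beyond the scatter, an estimated shift of a number no higher from compound 2 to compound 3 (the limit leaves the size open). Compound 3 is accordingly estimated at 200000 nM in this assay, within a range from 50000 nM to 400000 nM, with the greater chance being that the assay again reports only a limit.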

Compound 3, half-maximal inhibitory concentration: 200000 nM
Compound 3: middle estimate and measured number agree at the digits printed; low and high end bracket the measured number.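

In this assay, among these compounds, compound 3 gives 200000 nM, the only value shown that is a number and not a limit, so acetyl at this place, on an aromatic carbon para to a large group, yields a reading on the scale. Compound 2 gives > 200000 nM, which is a limit of the assay and not a number. The change from bromo to acetyl therefore shows a number no higher from compound 2 to compound 3 (the limit leaves the size open), and its size cannot be read because most of the values shown offer no measured starting point: the limit of > 200000 nM in this assay, at which 2 of the 3 values shown sit.

On these data alone, whether an amine or a carboxylic acid in place of the acetyl would give a clearly stronger inhibitor remains open. Also open, as far as these compounds go, is whether a longer chain on the acetyl, or any change elsewhere on the shared core, would move the value of compound 3 beyond the usual scatter of this assay.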